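Side-chain amine variation in a chloroquinoline-type butylamino series

This account rests on a few compounds, and the source may have more. Where it says the series, first, only, none or still open, it means among the compounds named here.

Measured compounds:
- compound 1 `CCCCNc1ccnc2cc(Cl)ccc12`: 12300 nM in a functional assay on MDA-MB-231 cells (Homo sapiens) for cytotoxicity, read by sulforhodamine B assay, with a stated time of 48 h, in the presence of a further agent that is not named here; a higher number here means a weaker inhibitor of growth, a lower number a stronger inhibitor of growth
- compound 2 `CCCCNc1ccnc2cc(F)ccc12`: 7250 nM in this assay

Of the two numbers, that of compound 1 is the higher, though the step of a 1.7-fold lower number from compound 1 to compound 2 (0.23 log units; within the scatter) lies within the scatter, so the two compounds cannot be separated on this evidence. Compound 3 `CN(C)CCNc1ccnc2cc(Cl)ccc12` differs from compound 1 by dimethylamino in place of ethyl on a saturated chain carbon, two bonds along the chain from a nitrogen on an aromatic ring. Going by the values given here, the only measured step concerns fluoro in place of chloro on an aromatic carbon and does not touch the chain on the ring nitrogen, so no measured step bears on this change. With nothing to anchor a direction, the expected step of a 1.2-fold lower number from compound 1 to compound 3 (0.09 log units; within the scatter) is none beyond the scatter, with a wide margin. Compound 3 is therefore estimated at 10000 nM in this assay, expected to fall between 2500 nM and 40000 nM.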

Compound 3, concentration for 50% growth inhibition: 5660 nM
For compound 3 the middle estimate is 1.8-fold (0.25 log units) above the measured one; the measured number falls inside the stated range.
By their numbers in this assay, from the lowest: compounds 3, 2 and 1 (each within the scatter of the next, the first and the last beyond it).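

In this assay, going by these compounds alone, the chain change gives a 2.2-fold lower number from compound 1 to compound 3 (0.34 log units; beyond the scatter), the first step that lies beyond the scatter. Within the data shown here, the step is modest, but it shows that this saturated chain position responds to the change from butyl to 2-(dimethylamino)ethyl, whereas the only earlier step, on an aromatic carbon, could not be separated from the scatter. Nothing at hand accounts for the shift.

From the compounds shown here alone, it remains open whether the step follows from the dimethylamino group specifically or would also appear with another end group, such as a primary amine, diethylamino or morpholine, or with a longer chain carrying the dimethylamino group. Also open, going by these compounds, is whether the step would hold with fluoro in place of chloro on the shared core.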